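The compounds below may be only part of what the source reports. "The series", "measured", "known", "first", "only" and "open" are said of these compounds alone.

Measured compounds:
- compound 1, `CCOC(=O)C1CCCN(C(=O)CN2CN(c3ccccc3)C3(CCN(C(=O)c4ccc(C5CCCCC5)cc4)CC3)C2=O)C1`: 4200 nM
- compound 2, `O=C(CN1CN(c2ccccc2)C2(CCN(C(=O)c3ccc(C4CCCCC4)cc3)CC2)C1=O)NCO`: 8300 nM

Both compounds were tested in an assay on HEK293 cells for displacement of a labelled ligand from NPC1-like intracellular cholesterol transporter 1 (Homo sapiens); on this read-out lower numbers stand for stronger inhibition and higher numbers for weaker inhibition. Among the measured compounds shown here, of the two numbers, compound 2 has the higher one, and its only neighbour is compound 1, whose value is within the scatter of it. For the measured compounds named here, the single measured step, a 2.0-fold higher number from compound 1 to compound 2 (0.30 log units; within the scatter), exchanged the group attached to the amide carbonyl and did not move the number beyond the scatter.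

Compound 3, `NCCNC(=O)CN1CN(c2ccccc2)C2(CCN(C(=O)c3ccc(C4CCCCC4)cc3)CC2)C1=O`, differs from compound 2 at that same end of the molecule: aminomethyl in place of hydroxy on a saturated chain carbon bound to an amide-type nitrogen. Going by the values given here, no measured pair shows this particular exchange, so it cannot be read off directly. Among the compounds with values here, the only guide is the one step seen so far, which changed the group at this carbonyl-bound position far more drastically and still stayed within the scatter, while the shared core is untouched in all three compounds. On that basis no step beyond the scatter is expected in this assay for the change from compound 2 to compound 3, in either direction. The step that this estimate means, a 1.1-fold lower number from compound 2 to compound 3 (0.04 log units; within the scatter), is expected to stay within the scatter. Compound 3 is therefore expected to give 7500 nM, within a range from 2500 nM to 22000 nM.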

Compound 3, half-maximal inhibitory concentration: 3800 nM
Compound 3: middle estimate off by 2.0-fold (0.30 log units), on the high side; measured number inside the range.
By their numbers in this assay, from the lowest: compounds 3, 1 and 2 (each within the scatter of the next, the first and the last beyond it).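

Swapping hydroxy for aminomethyl on a saturated chain carbon bound to an amide-type nitrogen, which turns hydroxymethyl into 2-aminoethyl, gives the first step at this end of the molecule to pass beyond the scatter in this assay: a 2.2-fold lower number from compound 2 to compound 3 (0.34 log units; beyond the scatter). The step is modest and rests on a single pair, but it shows that a small exchange can register here, whereas the far larger exchange of the whole group on the carbonyl carbon seen earlier did not. The comparison with the first compound tempers this: (2-aminoethyl)amino in place of 3-(ethoxycarbonyl)piperidin-1-yl on a carbonyl carbon gives a 1.1-fold lower number from compound 1 to compound 3 (0.04 log units; within the scatter), so these two groups cannot be told apart on this read-out, and nothing available accounts for the shift seen in the other step.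

As far as these compounds go, the exchange alters the chain and its end group together, so it remains open whether the amine or the longer chain matters; a 2-hydroxyethyl group in the same place would separate the two. Also open, from the compounds shown here alone, is how a 3-aminopropyl group or a carboxylic acid would behave here.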